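The source may report more compounds than this note shows. Statements on the series, on what has been measured and on what is new or still open speak of the compounds shown alone.

Of the compounds shown here, three have so far been tested in a functional assay on MDA-MB-231 cells (Homo sapiens) for inhibition, read by sulforhodamine B assay, tested at 10 uM; on this read-out lower numbers stand for less inhibition and higher numbers for more inhibition at the one concentration tested (going by the name of the read-out). Compound 1 `CC(=O)N1N=C(c2ccc(N3CCN(C)CC3)cc2)CC1c1ccc(N(C)C)cc1` gives -1% in this assay, compound 2 `CN1CCN(c2ccc(C3=NN(S(C)(=O)=O)C(c4ccc(N(C)C)cc4)C3)cc2)CC1` gives 0.6%, and compound 3 `CN1CCN(c2ccc(C3=NN(S(=O)(=O)c4ccc(Br)cc4)C(c4ccc(N(C)C)cc4)C3)cc2)CC1` gives 23.7%. Compound 3 therefore stands highest of the three numbers: the step of a number 24.7 percentage points higher from compound 1 to compound 3 (beyond the scatter) and the step of a number 23.1 percentage points higher from compound 2 to compound 3 (beyond the scatter) both lie beyond the scatter, whereas the step of a number 1.6 percentage points higher from compound 1 to compound 2 (within the scatter) does not. All three share the same core and differ only in the group attached to the ring nitrogen.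

Compound 4 `CN1CCN(c2ccc(C3=NN(S(=O)(=O)c4ccc(C#N)cc4)C(c4ccc(N(C)C)cc4)C3)cc2)CC1` has not yet been measured. It differs from compound 3 in one place: cyano in place of bromo on an aromatic carbon. Among the measured compounds shown here, none of the measured steps bears directly on this change. For the measured compounds named here, the two steps beyond the scatter exchanged the whole group on the ring nitrogen, bringing in the (4-bromophenyl)sulfonyl group, and the step within the scatter swapped acetyl for methylsulfonyl; no measured pair alters the group at the far end of that aromatic ring. With the (4-cyanophenyl)sulfonyl group keeping the sulfonyl and aromatic ring of compound 3, no step beyond the scatter is expected in this assay in either direction. Compound 4 is thus expected to give about 22% in this assay, within a range from 8% to 38%. That expectation corresponds to a step of a number 1.7 percentage points lower from compound 3 to compound 4 (within the scatter).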

Compound 4, a percentage reported as inhibition, at one concentration (the size of the read-out at that concentration, not a potency): 99.8%
The estimate for compound 4 lay 77.8 percentage points below the measured number; measured number outside the range, above it.
By their numbers in this assay, from the lowest: compounds 1 and 2 (each within the scatter of the next); then compound 3; then compound 4.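

In this assay the group at the far end of the aromatic ring proves decisive: with the sulfonyl and the ring kept, replacing bromo with cyano on an aromatic carbon, para to a large group, gives a number 76.1 percentage points higher from compound 3 to compound 4 (beyond the scatter) in a single small change. The earlier comparison with a methyl on the sulfonyl sulfur, a number 23.1 percentage points higher from compound 2 to compound 3 (beyond the scatter) for the 4-bromophenyl group, could not show this, whereas the 4-cyanophenyl group gives a number 99.2 percentage points higher from compound 2 to compound 4 (beyond the scatter) and the whole (4-cyanophenyl)sulfonyl group in place of acetyl gives a number 100.8 percentage points higher from compound 1 to compound 4 (beyond the scatter) for these compounds. So, among these four compounds, an aromatic ring on the sulfonyl is not the whole story, and nothing available explains why this one exchange has so large an effect.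

As far as these compounds go, it remains open whether the high number is particular to cyano or would also appear with a nitro group, a carboxylic acid, an amine or a longer chain at this position. A read-out at one concentration also leaves open how compound 4 would behave at lower concentrations.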